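A few compounds are considered here, and "the series" means these few. Any claim that something is new, unique, unknown or untested is made for them only; others in the source may bear on it.

For the measured compounds named here, in a functional assay on MCF7 cells (Homo sapiens) for antiproliferative activity, read by sulforhodamine B assay, with a stated time of 48 h (on this read-out lower numbers stand for stronger inhibition and higher numbers for weaker inhibition), compound 1 `CN1CCN(c2ccc(S(=O)(=O)Oc3cccc(I)c3)cc2)C1=O` gives 560 nM, the only actual number so far. Compound 2 `CN1CCN(c2ccc(S(=O)(=O)Oc3ccc(F)cc3)cc2)C1=O` gives > 100000 nM, which is a limit of the assay and not a number. Compound 3 `CN1CCN(c2ccc(S(=O)(=O)Oc3ccc(Cl)cc3)cc2)C1=O` gives > 100000 nM, again a limit. Compound 1 therefore stands alone against (the limit of > 100000 nM in this assay, at which 2 of the 3 values shown sit).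

Compound 4 `CCN1CCN(c2ccc(S(=O)(=O)Oc3cccc(I)c3)cc2)C1=O` keeps the 3-iodophenyl of compound 1 and carries methyl in place of hydrogen on a saturated chain carbon bound to an amide-type nitrogen in a ring, which turns methyl to ethyl on the 2-oxoimidazolidin-1-yl group.

Two measured steps are large: an at least 170-fold higher number from compound 1 to compound 2 (2.25 log units; beyond the scatter), with 4-fluorophenyl in place of 3-iodophenyl, and an at least 170-fold higher number from compound 1 to compound 3 (2.25 log units; beyond the scatter), with 4-chlorophenyl in place of 3-iodophenyl. With chloro in place of fluoro, the remaining comparison is a step that the two limits leave unreadable from compound 2 to compound 3. All of these changes fall at the group on the oxygen, and none touches the place altered in compound 4, so their size does not carry over directly. They do show that this assay can move sharply within this series, which argues for a wide range.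

The expected step is a 1.3-fold higher number from compound 1 to compound 4 (0.10 log units; within the scatter), a slightly higher number but nothing beyond the scatter. For compound 4 the estimate is 700 nM, with an expected range from 200 nM to 2500 nM.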

Compound 4, half-maximal inhibitory concentration: 1900 nM
For compound 4 the middle estimate is 2.7-fold (0.43 log units) below the measured one; the measured number falls inside the stated range.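

In this assay, for the compounds shown here, the 3-methyl-2-oxoimidazolidin-1-yl group of compound 1 proves sensitive to change: replacing it with the 3-ethyl-2-oxoimidazolidin-1-yl group of compound 4 gives a 3.4-fold higher number from compound 1 to compound 4 (0.53 log units; beyond the scatter) and so marks a place that the earlier compounds left untouched as one that can shift the read-out. One added methyl, a single carbon with no ring, is enough to weaken inhibition beyond the scatter, although the step is modest. Compound 4 also keeps a measured value rather than a limit, so this change leaves the 3-iodophenyl compound with readable activity, and nothing shown here accounts for the size of the step.

The compounds shown hold only methyl and ethyl at this place, so a single step gives a direction but no trend with chain size, and a propyl chain, a 2-hydroxyethyl chain or a plain amide hydrogen would test whether the weakening continues, levels off or reverses. As far as these compounds go, whether the change from methyl to ethyl has the same effect with groups on the oxygen other than 3-iodophenyl also remains open.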